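This account rests on a few compounds, and the source may have more. Where it says the series, first, only, none or still open, it means among the compounds named here.

Measured so far in an ADME assay on Caco-2 cells (Homo sapiens) for permeability, read by LC-MS, in the apical to basolateral direction, with a stated time of 60 min, at pH 6.5; a higher number here means that the compound crosses the layer faster, a lower number that the compound crosses the layer more slowly:

- compound 1 `O=C(NCc1cc(Cl)ccc1-n1cnnn1)[C@@H]1CC=NN1C(=O)[C@H](O)c1ccccc1` gives 7 10^-6 cm/s
- compound 2 `CC1(C[C@@H](O)C(=O)N2N=CC[C@H]2C(=O)NCc2cc(Cl)ccc2-n2cnnn2)CC1` gives 9.5 10^-6 cm/s
- compound 3 `O=C(NCc1cc(Cl)ccc1-n1cnnn1)[C@@H]1C[C@@H]2C[C@@H]2N1C(=O)[C@H](O)C1CCCCC1` gives 16 10^-6 cm/s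

Compound 2 stands in the middle of these three numbers, with both others within the scatter of it. Compound 4 `O=C(NCc1cc(Cl)ccc1-n1cnnn1)[C@@H]1CC=NN1C(=O)[C@H](O)Cc1ccccc1` differs from compound 2 in one place: phenyl in place of 1-methylcyclopropyl on a saturated chain carbon, two bonds along the chain from a carbonyl carbon and an oxygen on a saturated carbon. In words, this is phenyl in place of 1-methylcyclopropyl on a saturated chain carbon, two bonds along the chain from a carbonyl carbon and an oxygen on a saturated carbon. Among the measured compounds shown here, the one measured step that bears on this is a 1.4-fold higher number from compound 1 to compound 2 (0.13 log units; within the scatter), with (1-methylcyclopropyl)methyl in place of phenyl. As that step stayed within the scatter, no change beyond the scatter is expected in this assay. The estimated 1.2-fold lower number from compound 2 to compound 4 (0.07 log units; within the scatter) is expected to stay inside it. For compound 4 the expected value is 8 10^-6 cm/s with an estimated range of 4 10^-6 cm/s to 15 10^-6 cm/s as the likely span.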

Compound 4, apparent permeability: 11 10^-6 cm/s
Beside the measured number, compound 4's estimate is 1.4-fold (0.14 log units) below it; the range from low to high includes it.
By their numbers in this assay, from the lowest: compounds 1, 2, 4 and 3 (each within the scatter of the next, the first and the last beyond it).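

In this assay, phenyl in place of 1-methylcyclopropyl gives a 1.2-fold higher number from compound 2 to compound 4 (0.06 log units; within the scatter) and benzyl in place of phenyl gives a 1.6-fold higher number from compound 1 to compound 4 (0.20 log units; within the scatter), so both changes stay within the scatter. At this position, phenyl, benzyl and (1-methylcyclopropyl)methyl on the shared core are therefore not told apart by this read-out. No measurement shown here offers an explanation for these small steps.

As far as these compounds go, whether an amine or a carboxylic acid at this place would carry the number beyond the scatter remains open.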